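The source may report more compounds than this note shows. Statements on the series, on what has been measured and on what is new or still open speak of the compounds shown alone.

Measured in a functional assay on DU-145 cells (Homo sapiens) for cytotoxicity, read by CCK-8 assay; a higher number here means a weaker inhibitor, a lower number a stronger inhibitor:
- Compound 1 `Oc1ccc(-c2cc(-c3cccs3)cc(-c3ccccc3O)n2)cc1`: > 50000 nM
- Compound 2 `Oc1ccc(-c2cc(-c3cccs3)cc(-c3cccc(O)c3)n2)cc1`: 1890 nM
- Compound 3 `Oc1ccc(-c2cc(-c3cccs3)cc(-c3ccc(O)cc3)n2)cc1`: 2190 nM

Compound 1 has no exact number, only a limit: the limit of > 50000 nM in this assay, at which 1 of the 3 values shown sits. Compound 4 `Oc1ccc(-c2cc(-c3ccco3)cc(-c3ccccc3O)n2)cc1` differs from it in one place: furan-2-yl in place of thiophen-2-yl on an aromatic carbon. The measured steps were large for two changes, an at least 26-fold lower number from compound 1 to compound 2 (1.42 log units; beyond the scatter) and an at least 22-fold lower number from compound 1 to compound 3 (1.35 log units; beyond the scatter), while a 1.2-fold higher number from compound 2 to compound 3 (0.06 log units; within the scatter) stayed within the scatter. All three exchange hydroxyphenyl groups, so none tests replacing thiophen-2-yl. Compound 4 keeps the 2-hydroxyphenyl group of compound 1, whose value is > 50000 nM, so it is expected to stay weak. The expected step, with none beyond the scatter foreseen, is a number no higher from compound 1 to compound 4 (the limit leaves the size open). Compound 4 is estimated at 50000 nM, with an expected range of 15000 nM to 100000 nM.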

Compound 4, half-maximal inhibitory concentration: > 50000 nM
Compound 4: only a limit was reported; the forecaster's own chance of this, stated with the estimate: 60%; the middle value sits exactly at the limit.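

Compound 1 and compound 4 each carry only a limit, so the step between them cannot be read: the limit of > 50000 nM in this assay, at which 2 of the 4 values shown sit.

The compounds shown leave open how furan-2-yl compares with thiophen-2-yl, both here and alongside a 3-hydroxyphenyl or 4-hydroxyphenyl group.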